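From a tert-butyl ketone to a fluorophenyl ketone

The compounds below may be only part of what the source reports. "The series", "measured", "known", "first", "only" and "open" are said of these compounds alone.

Compound 2 `CC(C)(C)C(=O)c1sc2nc(-c3cccs3)ccc2c1N` and compound 1 `COc1ccc(C(=O)c2sc3nc(-c4cccs4)ccc3c2N)cc1` share one core and differ only in the group attached to the carbonyl carbon. In a functional assay on WI-38 VA13 cells (Homo sapiens) for cytotoxicity (on this read-out lower numbers stand for an effect already at smaller amounts and higher numbers for an effect only at larger amounts of compound), compound 2 gives 0.57 ug/mL, while compound 1 gives 0.77 ug/mL. The step of a 1.4-fold lower number from compound 1 to compound 2 (0.13 log units; within the scatter) shows that the two numbers cannot be told apart, so compound 2 sits at the lower end of the two numbers but only within the scatter of compound 1. Compound 3 `Nc1c(C(=O)c2cccc(F)c2)sc2nc(-c3cccs3)ccc12` is not yet measured; the change leading to it is 3-fluorophenyl in place of tert-butyl on a carbonyl carbon. Within the data shown here, the single measured step bears on this, since it exchanged an aromatic group for tert-butyl and moved the number by a 1.4-fold lower number from compound 1 to compound 2 (0.13 log units; within the scatter) only. For compound 3 the expected step is a 1.2-fold higher number from compound 2 to compound 3 (0.09 log units; within the scatter), that is, nothing beyond the scatter. In this assay compound 3 is estimated at 0.7 ug/mL, with a range from 0.3 ug/mL to 1.6 ug/mL.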

Compound 3, half-maximal effective concentration: 0.025 ug/mL
Beside the measured number, compound 3's estimate is 28-fold (1.45 log units) above it; the whole stated range lies above it.
By their numbers in this assay, from the lowest: compound 3; then compounds 2 and 1 (each within the scatter of the next).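

Up to this point, the group on the carbonyl carbon seemed to matter little, but in this assay the change to 3-fluorophenyl gives a 23-fold lower number from compound 2 to compound 3 (1.36 log units; beyond the scatter) and shows that this position can shift the number strongly. An aromatic ring alone does not go with the shift: compound 1, with its 4-methoxyphenyl, stays within the scatter of compound 2, whereas exchanging one substituted phenyl for the other gives a 31-fold lower number from compound 1 to compound 3 (1.49 log units; beyond the scatter) and so shows that what the ring carries counts. Nothing available explains why 3-fluorophenyl stands apart in this way.

Going by these compounds, it remains open whether the fluorine itself is needed, or whether plain phenyl, or a phenyl carrying chlorine or an amine, would give a similar number. On these data alone, it is also open whether the same order would hold in any other cell line.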